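This account rests on a few compounds, and the source may have more. Where it says the series, first, only, none or still open, it means among the compounds named here.

Measured so far in an assay on HEK293 cells for inhibition of transient receptor potential cation channel subfamily M member 8 (Homo sapiens), read by FLIPR and calcium flux; on this read-out lower numbers stand for stronger inhibition and higher numbers for weaker inhibition:
compound 1 `CCN(C(=O)c1ccccc1OCc1ccccc1)C1CCNCC1` gives > 5000 nM, a limit of the assay.
compound 2 `CN(C(=O)c1ccccc1OCc1ccccc1)[C@@H]1CCNC1` gives > 10000 nM, likewise a limit.
compound 3 `CN(C(=O)c1ccccc1OCc1ccccc1)[C@@H]1CCC[C@H](N)C1` gives 3670 nM.

Among the compounds with values here, compound 3 thus holds the only number in this assay; the other two results sit at limits (the limit of > 10000 nM in this assay, at which 1 of the 3 values shown sits, and (the limit of > 5000 nM in this assay, at which 1 of the 3 values shown sits)). Within the data shown here, the single measured step, an at least 2.7-fold lower number from compound 2 to compound 3 (0.43 log units; beyond the scatter), concerns the ring on the amide-type nitrogen, not its alkyl chain. Compound 4 `CCCN(C(=O)c1ccccc1OCc1ccccc1)[C@@H]1CCC[C@H](N)C1` differs from compound 3 by ethyl in place of hydrogen on a saturated chain carbon bound to an amide-type nitrogen. Among the measured compounds shown here, no measured step bears on this change, so no shift beyond the scatter is expected in this assay; the step from compound 3 to compound 4 is estimated at a 1.0-fold lower number from compound 3 to compound 4 (0.02 log units; within the scatter). Compound 4 is therefore expected to give about 3500 nM, with a range from 1200 nM to 10000 nM.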

Compound 4, antagonist equilibrium constant: 1430 nM
Compound 4: the middle estimate sits 2.4-fold (0.39 log units) above what was measured; the measured number falls inside the stated range.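

In this assay, within the data shown here, the chain on the amide-type nitrogen counts as well as the ring: going from methyl to propyl with the 3-aminocyclohexyl ring kept gives a 2.6-fold lower number from compound 3 to compound 4 (0.41 log units; beyond the scatter) and this is the first measured step at this position. Among these compounds, the only earlier step concerned the ring on that nitrogen. Nothing shown gives a reason for this shift. The compounds shown leave open whether a longer chain such as butyl, or a branched one such as isopropyl, would lower the number further or raise it again.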